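Aryl swap on the core of compound 3

The compounds below may be only part of what the source reports. "The series", "measured", "known", "first", "only" and "open" are said of these compounds alone.

Among the measured compounds shown here, compound 3 `Cn1cc(-c2coc(C3CCNCC3)n2)c2ccccc21` gives 578000 nM in a functional assay on PC-3 cells (Homo sapiens) for cytotoxicity, read by MTT assay, with a stated time of 48 h (on this read-out higher numbers stand for weaker inhibition and lower numbers for stronger inhibition), the highest of the three numbers so far. Compound 2 `c1ccc2c(-c3coc(C4CCNCC4)n3)c[nH]c2c1` gives 407000 nM, and the step of a 1.4-fold higher number from compound 2 to compound 3 (0.15 log units; within the scatter) lies within the scatter. Compound 1 `Clc1ccc(-c2nc(-c3c[nH]c4ccccc34)co2)cc1` gives 151000 nM, the lowest of the three. Compound 4 `Cn1cc(-c2coc(-c3ccc(Cl)cc3)n2)c2ccccc21` differs from compound 3 by 4-chlorophenyl in place of piperidin-4-yl on an aromatic carbon. For the measured compounds named here, the only measured step that bears on this change is a 2.7-fold higher number from compound 1 to compound 2 (0.43 log units; beyond the scatter), which runs in the opposite direction; since compound 2 and compound 3 differ only by the methyl on an aromatic nitrogen and sit within the scatter of each other, the same exchange on the core of compound 3 is expected to reverse that step. Compound 4 is therefore expected to give a lower number, a 2.7-fold lower number from compound 3 to compound 4 (0.43 log units; beyond the scatter), an estimate of 214000 nM with a range of 100000 nM to 450000 nM.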

Compound 4, half-maximal inhibitory concentration: 302000 nM
Compound 4: the middle estimate sits 1.4-fold (0.15 log units) below what was measured; the measured number falls inside the stated range.
By their numbers in this assay, from the lowest: compounds 1, 4, 2 and 3 (each within the scatter of the next, the first and the last beyond it).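

In this assay, 4-chlorophenyl in place of piperidin-4-yl on the methylated core gives a 1.9-fold lower number from compound 3 to compound 4 (0.28 log units; within the scatter), so on this core the step alone does not separate the two groups. Across the two cores, the size of this exchange holds within the scatter: the same change on two cores in this assay, a 2.7-fold higher number (0.43 log units; beyond the scatter) from compound 1 to compound 2 and a 1.9-fold higher number (0.28 log units; within the scatter) from compound 4 to compound 3, 1.4-fold (0.15 log units) apart, within the scatter of two such steps. The methyl on the aromatic nitrogen, now also seen with 4-chlorophenyl, gives a 2.0-fold higher number from compound 1 to compound 4 (0.30 log units; within the scatter), and this step too reads alike on both cores: the same change on two cores in this assay, a 1.4-fold higher number (0.15 log units; within the scatter) from compound 2 to compound 3 and a 2.0-fold higher number (0.30 log units; within the scatter) from compound 1 to compound 4, 1.4-fold (0.15 log units) apart, within the scatter of two such steps. Still open, going by these compounds, is how a carboxylic acid or a longer chain ending in an amine would read on this aromatic carbon.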